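Dichlorophenyl sulfide in place of methoxyphenyl sulfide

This account rests on a few compounds, and the source may have more. Where it says the series, first, only, none or still open, it means among the compounds named here.

Compound 1 `Nc1cc(N)c2nc(-c3ccccc3)c(NCc3ccc(F)cc3)nc2c1` and compound 2 `COc1ccc(Sc2nc3cc(N)cc(N)c3nc2-c2ccccc2)cc1` share one core and differ at a single aromatic carbon. In a functional assay on SK-OV-3 cells (Homo sapiens) for inhibition, read by sulforhodamine B assay, with a stated time of 48 h (a higher number here means that more compound is tolerated, a lower number that less compound is tolerated), compound 1 gives 53700 nM. For compound 2 the this assay reports only a limit, < 100000 nM. The step that the limit leaves unreadable from compound 1 to compound 2 therefore cannot be sized, as the limit of < 100000 nM in this assay, at which 1 of the 2 values shown sits, shows. Compound 3 `Nc1cc(N)c2nc(-c3ccccc3)c(Sc3ccc(Cl)c(Cl)c3)nc2c1` carries 3,4-dichlorophenyl in place of 4-methoxyphenyl on a sulfur. Among the compounds with values here, no measured step touches this change, so no shift beyond the scatter is expected, and the starting point for compound 2 is itself only a limit. Compound 3 is therefore estimated at 50000 nM, within 15000 nM to 100000 nM. The expected step is a step that the limit leaves unreadable from compound 2 to compound 3.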

Compound 3, concentration lethal to 50% of the cells: < 100000 nM
Compound 3 was reported as a limit (the forecaster's own chance of this, stated with the estimate: 35%); the middle value is on the limit's open side.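

No step can be read between compound 1, compound 2 and compound 3, because compound 2 and compound 3 are reported only as limits: the limit of < 100000 nM in this assay, at which 2 of the 3 values shown sit.

Going by these compounds, how far the 3,4-dichlorophenyl and 4-methoxyphenyl sulfides really differ in this assay, and how either compares with compound 1, stays open.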